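Swapping the group on the sulfonyl sulfur

The source may hold more compounds than are shown below. What is called first, only, known or untested is meant among the compounds shown, and "the series" means these compounds.

Measured in a functional assay on K562 cells (Homo sapiens) for inhibition, read by trypan blue exclusion, with a stated time of 72 h; a lower number here means a stronger inhibitor, a higher number a weaker inhibitor
- compound 1 `Cn1c(=O)c(S(=O)(=O)c2ccc(Cl)cc2)cc2cnc(Nc3ccc4[nH]ccc4c3)nc21` gives 100 nM
- compound 2 `Cn1c(=O)c(S(=O)(=O)c2ccc(F)cc2)cc2cnc(Nc3ccc4[nH]ccc4c3)nc21` gives 200 nM
- compound 3 `Cc1ccc(S(=O)(=O)c2cc3cnc(Nc4ccc5[nH]ccc5c4)nc3n(C)c2=O)cc1` gives 750 nM

Compound 3 has the highest number of the three, which makes it the weakest inhibitor here. Compound 4 `Cn1c(=O)c(S(=O)(=O)Nc2ccc(F)cc2F)cc2cnc(Nc3ccc4[nH]ccc4c3)nc21` carries (2,4-difluorophenyl)amino in place of 4-methylphenyl on a sulfonyl sulfur. Within the data shown here, the measured steps change only one group on an aromatic carbon. They show a 2.0-fold higher number from compound 1 to compound 2 (0.30 log units; within the scatter) and a 7.5-fold higher number from compound 1 to compound 3 (0.88 log units; beyond the scatter) and also a 3.8-fold higher number from compound 2 to compound 3 (0.57 log units; beyond the scatter) for these swaps. None of them replaces the group on the sulfur, so they are only a loose guide. Compound 2, which bears fluoro, gives 200 nM in this assay so a modest move to a lower number is expected, with wide uncertainty. The expected change is a 2.1-fold lower number from compound 3 to compound 4 (0.33 log units; beyond the scatter) by this estimate. For compound 4 the estimated value is 350 nM with an expected range from 70 nM to 1800 nM in this measurement.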

Compound 4, half-maximal inhibitory concentration: 5000 nM
Estimate against measurement, compound 4: 14-fold (1.15 log units) below; measured number above the stated range.
By their numbers in this assay, from the lowest: compounds 1 and 2 (each within the scatter of the next); then compound 3; then compound 4.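

In this assay, among these compounds, the first change at the sulfur itself gives a 6.7-fold higher number from compound 3 to compound 4 (0.82 log units; beyond the scatter), a 25-fold higher number from compound 2 to compound 4 (1.40 log units; beyond the scatter) and a 50-fold higher number from compound 1 to compound 4 (1.70 log units; beyond the scatter). All three compounds with an aryl group directly on the sulfur therefore give lower numbers than compound 4, so this position tolerates the new group poorly. Nothing measured here explains the loss of potency.

From the compounds shown here alone, this single swap adds the amino link and changes the ring substituents together, so their separate contributions remain unknown. Going by these compounds, how a plain phenylamino group or a piperidine on the sulfur would compare also stays open.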